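The source may report more compounds than this note shows. Statements on the series, on what has been measured and on what is new or still open speak of the compounds shown alone.

Of the compounds shown here, two have been measured here. Compound 1 `COc1cc(-c2nn(-c3cccc(NC(=O)c4cccc(C(F)(F)F)c4)c3)cc2-c2ccncc2)ccc1Cl` gives 32500 nM in a functional assay on NCI-H23 cells (Homo sapiens) for inhibition, read by sulforhodamine B assay, with a stated time of 48 h (a higher number here means a weaker inhibitor of growth, a lower number a stronger inhibitor of growth), the higher of the two numbers recorded. Compound 2 `O=C(Nc1cccc(-n2cc(-c3ccncc3)c(-c3ccc(Cl)c(O)c3)n2)c1)Nc1cc(C(F)(F)F)cc(C(F)(F)F)c1`, which carries a urea linker instead of an amide and a hydroxyl in place of the methoxy group, gives 3270 nM in this assay, a lower number that lies beyond the usual scatter of such measurements.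

Compound 3 `COc1cc(-c2nn(-c3cccc(NC(=O)Nc4ccc(Cl)c(C(F)(F)F)c4)c3)cc2-c2ccncc2)ccc1Cl` has not been measured. It differs from compound 1 in one place: (4-chloro-3-(trifluoromethyl)phenyl)amino in place of 3-(trifluoromethyl)phenyl on a carbonyl carbon. The result is a urea linker of the same kind found in compound 2. No measured pair isolates this change on its own, so the direction is taken from the pattern shown by compound 2, whose 3270 nM sits well below that of compound 1. For compound 3 a stronger growth inhibitor is therefore expected, with a step of a 6.5-fold lower number from compound 1 to compound 3 (0.81 log units; beyond the scatter) in this assay, giving an estimated value of 5000 nM, likely between 1500 nM and 17000 nM.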

Compound 3, concentration for total growth inhibition: 8030 nM
The estimate for compound 3 lay 1.6-fold (0.21 log units) below the measured number; measured number inside the range.
By their numbers in this assay, from the lowest: compound 2; then compound 3; then compound 1.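

In this assay, the replacement of 3-(trifluoromethyl)phenyl on a carbonyl carbon by (4-chloro-3-(trifluoromethyl)phenyl)amino gives a 4.0-fold lower number from compound 1 to compound 3 (0.61 log units; beyond the scatter). Within the data shown here, this is the first single-place comparison in the set, and it shows that growth inhibition responds to a change at this position while the rest of compound 1 stays the same. No measurement shown here accounts for the step.

The change brings in the amino nitrogen and the chlorine together, so the compounds shown cannot say how much of the step belongs to either one. Also open, from the compounds shown here alone, is what a methylene group in place of the amino nitrogen, or a methyl group or a fluorine in place of the chlorine, would do in this assay.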